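Swapping the amide aryl group in a sulfonamide series

A few compounds are considered here, and "the series" means these few. Any claim that something is new, unique, unknown or untested is made for them only; others in the source may bear on it.

Measured compounds:
compound 1, `COc1ccc(S(=O)(=O)N2CCc3cccc(NC(=O)c4ccc([N+](=O)[O-])cc4)c32)cc1`, 102 nM
compound 2, `COc1ccc(S(=O)(=O)N2CCc3cccc(NCc4ccccc4)c32)cc1`, > 10000 nM

Within the data shown here, in a functional assay on KB cells (Homo sapiens) for cytotoxicity (on this read-out higher numbers stand for weaker inhibition and lower numbers for stronger inhibition), compound 1 gives 102 nM, the only full number among the two measured values. Compound 2 is reported only as a limit of the assay, > 10000 nM, and so the limit of > 10000 nM in this assay, at which 1 of the 2 values shown sits, is where it sits rather than a number. Among the measured compounds shown here, no step between measured compounds that differ in one place is available, so compound 1 stands alone as a reference.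

Compound 3, `COc1ccc(S(=O)(=O)N2CCc3cccc(NC(=O)c4ccco4)c32)cc1`, is not yet measured. It differs from compound 1 by furan-2-yl in place of 4-nitrophenyl on a carbonyl carbon. With nothing measured that speaks to such a swap, a moderate loss beyond the scatter is expected, and the step of a 3.9-fold higher number from compound 1 to compound 3 (0.59 log units; beyond the scatter) is the estimate. Compound 3 is expected to give about 400 nM in this assay, most likely between 100 nM and 2500 nM.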

Compound 3, half-maximal inhibitory concentration: 9.6 nM
Estimate against measurement, compound 3: 42-fold (1.62 log units) above, and the stated range ends above it.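

In this assay, the 4-nitrophenyl group on the carbonyl carbon proves not to be needed for activity: furan-2-yl in its place gives an 11-fold lower number from compound 1 to compound 3 (1.03 log units; beyond the scatter), so this position accepts a five-membered aromatic ring with 1 hetero atom. Putting (furan-2-yl)carbonyl in place of benzyl on a nitrogen on an aromatic ring gives an at least 1000-fold lower number from compound 2 to compound 3 (3.01 log units; beyond the scatter), but this one change replaces both the carbonyl and the aromatic ring attached to it, so neither can be credited alone. That step rests on a limit for compound 2, not on a full number: the limit of > 10000 nM in this assay, at which 1 of the 3 values shown sits.

The compounds shown do not tell whether the gain comes from the furan ring itself or from the loss of the nitro group. Plain phenyl, thiophene or pyridine on the same carbonyl carbon would help to separate these possibilities.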